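The source may hold more compounds than are shown below. What is called first, only, known or untested is meant among the compounds shown, and "the series" means these compounds.

Measured compounds:
compound 2 `CN1CCCC(n2cc(S(=O)(=O)c3cc(Cl)cc(Cl)c3)c3cccnc32)C1` — 38.7 nM
compound 1 `O=S(=O)(C1=C(Cl)NC2SC=CN12)c1cn(C2CCNC2)c2ncccc12` — 80 nM

Within the data shown here, in a functional assay on HeLa cells for agonist activity at 5-hydroxytryptamine receptor 6 (Homo sapiens), read by cAMP accumulation and immunoassay (on this read-out lower numbers stand for an effect already at smaller amounts and higher numbers for an effect only at larger amounts of compound), compound 2 gives 38.7 nM, the lowest of the two numbers so far; compound 1 gives 80 nM, and the gap between the two lies beyond the scatter. The step to compound 3 `CN1CCCC(n2cc(S(=O)(=O)C3=C(Cl)NC4SC=CN34)c3cccnc32)C1` is a group of 9 heavy atoms (5 carbon, 2 nitrogen, 1 sulfur, 1 chlorine; 2 five-membered non-aromatic rings with 2 hetero atoms each) in place of a group of 8 heavy atoms (6 carbon, 2 chlorine; one six-membered aromatic ring of carbon only), on a sulfonyl sulfur. Compound 1 already carries the group that enters, attached to a sulfonyl sulfur in the same way, but compound 1 and compound 3 also differ elsewhere, so the exchange is not seen in isolation among the measured compounds. The expectation rests on compound 1 giving 80 nM while carrying that entering group: compound 3 is expected to land near that number, somewhat above compound 2, with a fair chance that the move stays within the scatter. For compound 3 the expected step is a 1.8-fold higher number from compound 2 to compound 3 (0.26 log units; within the scatter), modest and toward higher numbers. Compound 3 is thus estimated at 70 nM, with a range from 25 nM to 200 nM.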

Compound 3, half-maximal effective concentration: 25 nM
For compound 3 the middle estimate is 2.8-fold (0.45 log units) above the measured one; the range from low to high includes it.
By their numbers in this assay, from the lowest: compounds 3 and 2 (each within the scatter of the next); then compound 1.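

In this assay, the group with 2 five-membered non-aromatic rings and the 3,5-dichlorophenyl group on the sulfonyl sulfur are not told apart: the exchange gives a 1.5-fold lower number from compound 2 to compound 3 (0.19 log units; within the scatter) and so shows that this position accepts two groups of quite different make-up with no change beyond the scatter. With that sulfonyl group held constant, 1-methylpiperidin-3-yl in place of pyrrolidin-3-yl on the aromatic nitrogen gives a 3.2-fold lower number from compound 1 to compound 3 (0.51 log units; beyond the scatter) as a modest step beyond the scatter, the first isolated sign that the group on this nitrogen affects the number in this series. No available data explain either step.

Open, going by these compounds, is whether the step on the aromatic nitrogen comes from ring size or from the methyl group, which piperidin-3-yl and 1-methylpyrrolidin-3-yl would separate, and whether it keeps its size with 3,5-dichlorophenyl on the sulfonyl sulfur. Also open, on these data alone, is how far the sulfonyl position tolerates other groups, such as unsubstituted phenyl or pyridyl, since two groups give only a narrow view of it.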